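The source may report more compounds than this note shows. Statements on the series, on what has been measured and on what is new or still open speak of the compounds shown alone.

Compound 1 `Cc1cc(C)cc(NC(=O)COc2cc(C)nc3ccc(Cl)cc23)c1` in a toxicity assay on HepG2 cells (Homo sapiens) for inhibition, read by CellTiter-Glo, with a stated time of 48 h (a lower number here means a stronger inhibitor, a higher number a weaker inhibitor), gives only a limit, > 100000 nM.
Compound 2 `COc1ccc2nc(C)cc(OC(C)C(=O)Nc3cc(C)cc(C)c3)c2c1` in this assay gives 39800 nM.
Compound 3 `COc1cccc(NC(=O)COc2cc(C)nc3ccc(OC)cc23)c1` in this assay gives only a limit, > 100000 nM.

Compound 3 thus does not stand at a number at all but at the limit of this assay, and the limit of > 100000 nM in this assay, at which 2 of the 3 values shown sit, is the mark where it sits together with compound 1. Only compound 2 returns a numeric reading, and that reading is itself weak. Nothing in this set separates any two members beyond the scatter.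

Compound 4 `COc1ccc2nc(C)cc(OCC(=O)Nc3ccncn3)c2c1` is the next member to be measured in this assay. It differs from compound 3 in one place: pyrimidin-4-yl in place of 3-methoxyphenyl on an amide-type nitrogen. Within the data shown here, no step between measured compounds is available to size this kind of change, and the set gives no instance of a shift beyond the scatter in either direction. Compound 4 is therefore expected to sit near the limit, estimated at 100000 nM, with a range from 30000 nM to 300000 nM. The step of a number no higher from compound 3 to compound 4 (the limit leaves the size open) is expected to be flat, with a limit the most likely outcome for compound 4.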

Compound 4, half-maximal inhibitory concentration: > 100000 nM
Compound 4 ended at the assay's limit; the forecaster's own chance of this, stated with the estimate: 70%; the middle value lies on the limit itself.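

In this assay compound 4 gives only a limit, > 100000 nM. Compound 3 also gives only a limit, > 100000 nM, so no step can be read between compound 3 and compound 4. From the compounds shown here alone, how far pyrimidin-4-yl in place of 3-methoxyphenyl on an amide-type nitrogen shifts the reading remains open.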